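Cyclopentenyl for trifluoromethyl on the quinolinone series

A few compounds are considered here, and "the series" means these few. Any claim that something is new, unique, unknown or untested is made for them only; others in the source may bear on it.

Measured so far in an assay on isolated protein for inhibition of tyrosine-protein kinase receptor UFO (Homo sapiens), read by FRET and Z'-LYTE, with a stated time of 1.5 h; a higher number here means a weaker inhibitor, a lower number a stronger inhibitor:

- compound 1, `Cc1c(C(=O)Nc2ccc(Oc3ncnc4[nH]cc(-c5ccccc5)c34)c(F)c2)c(=O)c2cc(C(F)(F)F)ccc2n1C`, gives 150 nM
- compound 2, `CCc1ccc2c(c1)c(=O)c(C(=O)Nc1ccc(Oc3ccnc4[nH]cc(-c5ccccc5)c34)c(F)c1)c(C)n2C`, gives 30 nM
- compound 3, `CCc1ccc2c(c1)c(=O)c(C(=O)Nc1ccc(Oc3ccnc(Cl)c3)c(F)c1)c(C)n2C`, gives only a limit of the assay, > 10000 nM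

Compound 1 holds the highest of the two numbers that were read out; compound 2 sits at a lower number, and that gap lies beyond the usual scatter. Compound 2 differs from compound 1 in more than one place, so its gap cannot be assigned to a single change. Compound 3 is known only through the limit of > 10000 nM in this assay, at which 1 of the 3 values shown sits, and gives no number to compare.

Compound 4, `Cc1c(C(=O)Nc2ccc(Oc3ncnc4[nH]cc(-c5ccccc5)c34)c(F)c2)c(=O)c2cc(C3=CCCC3)ccc2n1C`, is not yet measured. It differs from compound 1 as follows: cyclopent-1-en-1-yl in place of trifluoromethyl on an aromatic carbon.

Among the compounds with values here, no single-point step between measured compounds is available for this position. The expected step from compound 1 to compound 4 in this assay is small, a move toward a slightly lower number, of size a 1.5-fold lower number from compound 1 to compound 4 (0.18 log units; within the scatter), close to the edge of the scatter rather than clearly beyond it. Compound 4 is accordingly expected to give about 100 nM in this assay, with a plausible range from 30 nM to 400 nM.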

Compound 4, half-maximal inhibitory concentration: 3320 nM
Compound 4: middle estimate off by 33-fold (1.52 log units), on the low side; the whole stated range lies below it.
By their numbers in this assay, from the lowest: compound 2; then compound 1; then compound 4. At a limit, above all of these: compound 3.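

On the aromatic carbon that carries trifluoromethyl in compound 1, the group is not interchangeable: in this assay, cyclopent-1-en-1-yl in its place gives a 22-fold higher number from compound 1 to compound 4 (1.35 log units; beyond the scatter). This is the only step among the compounds shown that changes one place, so it is the first direct reading of how much this position matters, and the change is large. Compound 4 still gives a number rather than a limit, and nothing measured here bears on the cause of the step.

On these data alone, one step cannot separate the ring from the double bond or from the loss of fluorine, so it remains open whether a saturated cyclopentyl or a smaller methoxy group would read nearer compound 1 or compound 4. As far as these compounds go, whether the step carries over to the core of compound 2 is also open.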